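The compounds below may be only part of what the source reports. "The series", "measured", "known", "first", "only" and "open" are said of these compounds alone.

Three compounds share one core and differ only in the group on the outer benzene ring. Compound 1 `O=C(COc1ccc2c(=O)ccoc2c1)Nc1cccc(NC(=O)c2ccc(F)cc2)c1` gives 54 nM in an assay on isolated protein for inhibition of Rho-associated protein kinase 2 (Homo sapiens), read by scintillation counting, radiometric assay and 33P incorporation, with a stated time of 40 min, in the presence of a further agent that is not named here (on this read-out higher numbers stand for weaker inhibition and lower numbers for stronger inhibition), compound 2 `O=C(COc1ccc2c(=O)ccoc2c1)Nc1cccc(NC(=O)c2ccc(Br)cc2)c1` gives 49 nM, and compound 3 `COC(=O)c1ccc(C(=O)Nc2cccc(NC(=O)COc3ccc4c(=O)ccoc4c3)c2)cc1` gives 29 nM. Compound 3 holds the lowest of the three numbers, yet a 1.9-fold lower number from compound 1 to compound 3 (0.27 log units; within the scatter) and a 1.7-fold lower number from compound 2 to compound 3 (0.23 log units; within the scatter) were both within the scatter, so the three cannot be told apart on these data. Compound 4 `NCc1ccc(C(=O)Nc2cccc(NC(=O)COc3ccc4c(=O)ccoc4c3)c2)cc1` is not yet measured; it differs from compound 3 by aminomethyl in place of methoxycarbonyl on an aromatic carbon. Within the data shown here, the two earlier exchanges at this same place are the steps that bear on it, and neither moved the number beyond the scatter, so no step beyond the scatter is expected here either, namely a 1.0-fold higher number from compound 3 to compound 4 (0.01 log units; within the scatter) in this assay. The estimate for compound 4 is therefore 30 nM in this assay, with a range from 10 nM to 90 nM.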

Compound 4, half-maximal inhibitory concentration: 66 nM
Estimate against measurement, compound 4: 2.2-fold (0.34 log units) below; the range from low to high includes it.
By their numbers in this assay, from the lowest: compounds 3, 2, 1 and 4 (each within the scatter of the next, the first and the last beyond it).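

The exchange of methoxycarbonyl for aminomethyl is the only one shown at this position that moves the number beyond the scatter in this assay (a 2.3-fold higher number from compound 3 to compound 4 (0.36 log units; beyond the scatter)), though the step is modest. Aminomethyl stays within the scatter of both halogens (a 1.3-fold higher number from compound 2 to compound 4 (0.13 log units; within the scatter); a 1.2-fold higher number from compound 1 to compound 4 (0.09 log units; within the scatter)), so among these four compounds only the pair of compound 3 and compound 4 can be told apart. Nothing available explains the step from methoxycarbonyl to aminomethyl.

On these data alone, it remains open whether a carboxylic acid or a longer aminoethyl chain at this place would give a number closer to that of compound 3 or of compound 4. As far as these compounds go, the result for a primary amine attached directly to the ring also remains open.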